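The compounds below may be only part of what the source reports. "The series", "measured", "known", "first", "only" and "open" are said of these compounds alone.

Working notes on the series, all members sharing the core of compound 1 (`COc1cc(NC(C)CCCNC(=O)NCCCO)c2ncccc2c1`). In an ADME assay on L6 cells (Rattus norvegicus) for cytotoxicity, read by resazurin assay, with a stated time of 70 h (on this read-out lower numbers stand for stronger inhibition and higher numbers for weaker inhibition), compound 1 gives "not determined" (no result reported). Going by the values given here, in the same read-out compound 2 (`COc1cc(NC(C)CCCNC(=O)NNC(=O)/C(C)=C/c2ccccc2)c2ncccc2c1`) gives 36500 nM, which is the only number available so far. Compound 3 (`COc1cc(NC(C)CCCNC(=O)NNC(=O)NC2CCCC2)c2ncccc2c1`) gives "not determined" (no result reported). Compound 3 therefore has no single number, and like compound 1 it cannot be placed on the scale relative to compound 2.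

The next compound for this assay is compound 4 (`COc1cc(NC(C)CCCNC(=O)NNC(=O)Nc2cccc(Cl)c2)c2ncccc2c1`). The structural change is 3-chlorophenyl in place of cyclopentyl on an amide-type nitrogen. Among the compounds with values here, no measured pair differs in one place, so the data give no size for a change of this kind. With no number for its starting point, this step cannot be sized directly either. No step in either direction is expected to lie outside the usual scatter. Within the data shown here, the sole measured anchor is compound 2 at 36500 nM. The estimate for compound 4 is 30000 nM, with the result expected to fall between 10000 nM and 90000 nM.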

Compound 4, half-maximal inhibitory concentration: 58600 nM
Beside the measured number, compound 4's estimate is 2.0-fold (0.29 log units) below it; the measured number falls inside the stated range.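

In this assay the series now has its first readable step, and a 1.6-fold higher number from compound 2 to compound 4 (0.21 log units; within the scatter) comes with (3-chlorophenyl)amino in place of 1-methyl-2-phenylethenyl on a carbonyl carbon, so these two quite different groups cannot be told apart on this read-out. The step from compound 3 to compound 4 cannot be read, as compound 3 has no single number, and the change from cyclopentyl to 3-chlorophenyl on the amide-type nitrogen therefore still has no size. No supporting measurement bears on this result, and the step carries no explanation.

Two compounds with numbers cannot show whether this position is generally tolerant in this assay or whether these two groups merely happen to match. From the compounds shown here alone, it remains open whether an unsubstituted phenyl, a primary amine or a carboxylic acid at the end of a longer chain on the same amide-type nitrogen would stay within the scatter of compound 2 and compound 4 or move clearly beyond it.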